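The source may report more compounds than this note shows. Statements on the series, on what has been measured and on what is new or still open speak of the compounds shown alone.

Compound 1 `COc1cc2cc(Oc3ccc(NC(=O)Nc4cccc(C(F)(F)F)c4)cc3)c(C)nc2cc1OC` gives in a functional assay on IGROV-1 cells (Homo sapiens) for inhibition, read by sulforhodamine B assay, with a stated time of 48 h (a higher number here means that more compound is tolerated, a lower number that less compound is tolerated), the limit > 50000 nM.
Compound 2 `COc1cc2cc(Oc3ccc(NC(=O)Nc4ccc(Cl)c(C(F)(F)F)c4)cc3)c(C)nc2cc1OC` gives in this assay the limit > 32500 nM.

Going by the values given here, compound 2 therefore stands only at a limit of this assay, and the one other value shown is a limit as well. The step from compound 1 to compound 2, a step that the two limits leave unreadable from compound 1 to compound 2, is chloro in place of hydrogen on an aromatic carbon; its size is not readable because both ends are limits the limit of > 32500 nM in this assay, at which 1 of the 2 values shown sits, and (the limit of > 50000 nM in this assay, at which 1 of the 2 values shown sits). Compound 3 `COc1cc2cc(Oc3ccc(NC(=O)Nc4ccc(Cl)c(Cl)c4)cc3)c(C)nc2cc1OC` differs from compound 2 by chloro in place of trifluoromethyl on an aromatic carbon, ortho to a chloro group and meta to a large group. Among the compounds with values here, no measured step gives the size of such a change. Compound 3 is therefore expected to remain at a limit, with an estimate of 50000 nM in a range of 20000 nM to 200000 nM. The expected step is a step that the limit leaves unreadable from compound 2 to compound 3, none beyond the scatter.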

Compound 3, concentration lethal to 50% of the cells: > 100000 nM
Compound 3 was reported as a limit (the forecaster's own chance of this, stated with the estimate: 85%); middle value at least 2.0-fold (0.30 log units) from the limit.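

Going by these compounds alone, compound 1, compound 2 and compound 3 all stand only at limits in this assay, and no step among them can be read. The compounds shown leave open where the true lethal concentration of each compound lies.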